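The compounds below may be only part of what the source reports. "The series", "measured", "known", "first", "only" and "open" are said of these compounds alone.

Measured so far in a physicochemical assay for acid dissociation
Compound 1 `COc1cccc(Oc2ccc3c(NCCCNCc4ccco4)ccnc3c2)c1` gives 9.28
Compound 2 `Fc1ccc(Oc2ccc3c(NCCCNCc4ccco4)ccnc3c2)cc1` gives 9.28
Compound 3 `c1ccc(Oc2ccc3c(NCCCNCc4ccco4)ccnc3c2)cc1` gives 9.28

Compound 3 at 9.28 stands level with compound 1 and compound 2 at the digits shown. Compound 4 `c1coc(CNCCCNc2ccnc3cc(CC4CCCCC4)ccc23)c1` carries cyclohexylmethyl in place of phenoxy on an aromatic carbon and is still unmeasured. Among the compounds with values here, three measured steps bear on this change, though only indirectly: no change at the digits printed from compound 1 to compound 3 (within the scatter) and no change at the digits printed from compound 2 to compound 3 (within the scatter) and no change at the digits printed from compound 1 to compound 2 (within the scatter) for the series. Within the data shown here, none of them replaces the phenoxy group itself, so no direct precedent exists. The expected step in this assay is a number 0.02 log units higher from compound 3 to compound 4 (within the scatter) and none beyond the scatter is expected. Compound 4 is estimated at 9.3 with an expected range from 9 to 9.6 for this measurement.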

Compound 4, acid dissociation constant: 9.47
Estimate against measurement, compound 4: 0.17 log units below; measured number inside the range.
By their numbers in this assay, from the lowest: compounds 1, 2, 3 and 4 (each within the scatter of the next).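

In this assay, within the data shown here, the earlier compounds varied only the substituents on the phenoxy ring, whereas cyclohexylmethyl replaces the entire group on the aromatic carbon and gives a number 0.19 log units higher from compound 3 to compound 4 (within the scatter) in this comparison. The same holds for the two substituted groups, with a number 0.19 log units higher from compound 2 to compound 4 (within the scatter) for 4-fluorophenoxy and a number 0.19 log units higher from compound 1 to compound 4 (within the scatter) for 3-methoxyphenoxy, so a non-aromatic ring and the loss of the oxygen leave the read-out within the scatter. No supporting data explain this result.

Still open, as far as these compounds go, is how an amine or a carboxylic acid at this aromatic carbon would read in this assay for this series.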